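Replacing an Aryl Cap with a Carboxy Chain on a Dihydropyridine

The source may report more compounds than this note shows. Statements on the series, on what has been measured and on what is new or still open speak of the compounds shown alone.

The shared core, seen in compound 1 `CCOC(=O)C1=C(C)NC(C)=C(C(=O)OCC)C1c1ccc(OCC(=O)NNC(=O)c2ccc(C)cc2)cc1`, carries a hydrazide tail; compound 1 was tested in a functional assay on the whole organism (strain Wistar) for inhibition, with Rattus norvegicus as the target, read by paw edema, with stated times of 30 min and 2 h, at a dose of 20 mg/kg (on this read-out lower numbers stand for less inhibition and higher numbers for more inhibition at the one dose given (going by the name of the read-out)), where compound 1 gives 46.7%. Among the compounds with values here, of the two compounds measured so far, compound 1 holds the lower figure: compound 2 `CCOC(=O)C1=C(C)NC(C)=C(C(=O)OCC)C1c1ccc(OCc2nnc(S)o2)cc1`, which carries a different tail on the same core, gives 61.7% in this assay, a reading that lies beyond the usual scatter above that of compound 1. Within the data shown here, no pair of measured compounds differs in a single place, so no measured step guides the next comparison.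

Compound 3 `CCOC(=O)C1=C(C)NC(C)=C(C(=O)OCC)C1c1ccc(OCC(=O)NNC(=O)CCC(=O)O)cc1` has not yet been measured. Compared with compound 1, the change is 2-carboxyethyl in place of 4-methylphenyl on a carbonyl carbon. With nothing measured for this kind of exchange, the step from compound 1 to compound 3 a number 1.3 percentage points higher from compound 1 to compound 3 (within the scatter) is expected to be small, within the scatter, in either direction. Compound 3 is therefore estimated at 48%, between 30% and 66%.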

Compound 3, a percentage reported as inhibition, in the whole organism at one dose (the size of the read-out at that dose, not a potency): 57.8%
Beside the measured number, compound 3's estimate is 9.8 percentage points below it; low and high end bracket the measured number.
By their numbers in this assay, from the lowest: compound 1; then compounds 3 and 2 (each within the scatter of the next).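

In this assay, within the data shown here, the exchange of 4-methylphenyl for 2-carboxyethyl on a carbonyl carbon gives a number 11.1 percentage points higher from compound 1 to compound 3 (beyond the scatter), the first single-place step, and it shows that the aromatic cap is not required for this read-out and that this position responds to what sits on that carbonyl carbon. The other step, a number 3.9 percentage points lower from compound 2 to compound 3 (within the scatter), shows that a ring-free tail of 11 heavy atoms and a tail with a five-membered aromatic ring cannot be told apart here. No measurement available here accounts for the size of the first step.

Since the ring leaves as the carboxylic acid enters, the compounds shown do not separate the two parts of the change. A plain propyl chain on the same carbonyl carbon, or a longer carboxy chain, would bear on that question.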